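Swapping the Amide Substituent: From Cyclohexyl to Pyridinyl

The source may report more compounds than this note shows. Statements on the series, on what has been measured and on what is new or still open speak of the compounds shown alone.

Compound 1, `C#CCn1cc(C(=O)NC(CC(=O)Nc2ccccc2)c2ccccc2)c(=O)c2cc(F)c(Cl)nc21`, gives 6600 nM in a functional assay on K562 cells (Homo sapiens) for cytotoxicity, read by MTT assay, with a stated time of 72 h; a lower number here means a stronger inhibitor, a higher number a weaker inhibitor.
Compound 2, `C#CCn1cc(C(=O)NC(CC(=O)Nc2ccccn2)c2ccccc2)c(=O)c2ccc(Cl)nc21`, gives 5900 nM in this assay.
Compound 3, `C#CCn1cc(C(=O)NC(CC(=O)NC2CCCCC2)c2ccccc2)c(=O)c2cc(F)c(Cl)nc21`, gives 6200 nM in this assay.

Among these three numbers, compound 3 stands second highest, yet every gap between them lies within the scatter, so no ordering can be read from them. Among the compounds with values here, the one single-point step that has been measured, a 1.1-fold lower number from compound 1 to compound 3 (0.03 log units; within the scatter), shows that changing the group on the amide-type nitrogen left the number essentially unchanged. Compound 4, `C#CCn1cc(C(=O)NC(CC(=O)Nc2ccccn2)c2ccccc2)c(=O)c2cc(F)c(Cl)nc21`, is compound 3 with pyridin-2-yl in place of cyclohexyl on an amide-type nitrogen. Compound 2 carries the same pyridin-2-yl group on that nitrogen, and its value and that of compound 3 sit within the scatter of each other. Together these observations point to no step beyond the scatter in this assay, in either direction. The expected change, a 1.0-fold lower number from compound 3 to compound 4 (0.01 log units; within the scatter), is therefore essentially flat. Compound 4 is thus estimated at 6000 nM, with a likely range from 3000 nM to 12000 nM.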

Compound 4, half-maximal inhibitory concentration: > 10000 nM
Compound 4: a limit, no number (the forecaster's own chance of this, stated with the estimate: 5%); middle value at least 1.6-fold (0.22 log units) from the limit.
By their numbers in this assay, from the lowest: compounds 2, 3 and 1 (each within the scatter of the next). At a limit, above all of these: compound 4.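

In this assay compound 4 gives > 10000 nM, which is a limit of the assay and not a number, and it is the only such value here: the limit of > 10000 nM in this assay, at which 1 of the 4 values shown sits.

Swapping the group on the amide-type nitrogen had so far produced only a step within the scatter, whereas pyridin-2-yl in place of cyclohexyl now gives an at least 1.6-fold higher number from compound 3 to compound 4 (0.20 log units; that floor lies within the scatter), and pyridin-2-yl in place of phenyl gives an at least 1.5-fold higher number from compound 1 to compound 4 (0.18 log units; that floor lies within the scatter). Fluoro in place of hydrogen on an aromatic carbon, a change the earlier compounds could not test, gives an at least 1.6-fold higher number from compound 2 to compound 4 (0.22 log units; that floor lies within the scatter). Each of these is only a floor within the scatter, so none yet establishes a real change.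

A measured number for compound 4 would be needed to settle the true size of these steps. Also open, as far as these compounds go, is how pyridin-3-yl or benzyl on the same nitrogen would read in this assay.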